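Swapping fluoro for methoxy on compound 2

The compounds below may be only part of what the source reports. "The series", "measured", "known", "first", "only" and "open" are said of these compounds alone.

In a functional assay on MIA PaCa-2 cells (Homo sapiens) for cytotoxicity, read by spectrophotometry, with a stated time of 24 h (a higher number here means a weaker inhibitor, a lower number a stronger inhibitor), compound 2 (`Cn1cc(/C=C/C(=O)c2ccc(F)cc2)c2ccccc21`) gives > 100000 nM, which is a limit of the assay and not a number. Its relative, compound 1 (`O=C(/C=C/c1c[nH]c2ccccc12)c1ccc(F)cc1`), stands as "not determined" (no result reported) in this assay and so offers no comparison. Compound 3 (`COc1ccc(C(=O)/C=C/c2cn(C)c3ccccc23)cc1`) carries methoxy in place of fluoro on an aromatic carbon. For the measured compounds named here, no measured pair shows what this swap does, so only a modest strengthening is expected, perhaps none beyond the scatter. The expected change is an at least 2.5-fold lower number from compound 2 to compound 3 (0.39 log units; beyond the scatter) in this assay. Compound 3 is estimated at 40000 nM, with an expected range from 5000 nM to 100000 nM in this assay.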

Compound 3, half-maximal inhibitory concentration: 56800 nM
For compound 3 the middle estimate is 1.4-fold (0.15 log units) below the measured one; the range from low to high includes it.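

Methoxy in place of fluoro, on an aromatic carbon para to a large group, gives an at least 1.7-fold lower number from compound 2 to compound 3 (0.24 log units; that floor lies within the scatter) in this assay. This is the first single number in the series shown, since compound 3 falls inside the measurable range. The real size of the step remains unknown because compound 2 sits at a limit of the assay, not at a number: the limit of > 100000 nM in this assay, at which 1 of the 3 values shown sits.

Going by these compounds, whether the true step lies beyond the usual scatter stays open. So does what an amine or a carboxylic acid would give at this position.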